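The source may hold more compounds than are shown below. What is called first, only, known or untested is meant among the compounds shown, and "the series" means these compounds.

Compound 1, `Nc1ccc2cccc(OCCC(F)(F)F)c2n1`: in an assay on cells with melanin-concentrating hormone receptor 1 (Homo sapiens) as the target, read by radioligand binding (a higher number here means a weaker inhibitor, a lower number a stronger inhibitor), compound 1 gives 722 nM
Compound 2, `CC(C)Oc1cccc2ccc(N)nc12`: in this assay compound 2 gives 437 nM
Compound 3, `CC1CCC(Oc2cccc3ccc(N)nc23)C1`: in this assay compound 3 gives 823 nM

All three share one core and differ only in the group carried on an oxygen on an aromatic ring. Compound 3 has the highest of the three numbers, but its gaps to the other two are both within the scatter: a 1.1-fold higher number from compound 1 to compound 3 (0.06 log units; within the scatter) and a 1.9-fold higher number from compound 2 to compound 3 (0.27 log units; within the scatter). On these numbers the three compounds cannot be told apart.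

Compound 4, `CCOCC(C)Oc1cccc2ccc(N)nc12`, changes the same position once more: a group of 6 heavy atoms (5 carbon, 1 oxygen; no ring) in place of a group of 6 heavy atoms (6 carbon; one five-membered non-aromatic ring of carbon only), on an oxygen on an aromatic ring. The entering group has no ring and carries one hydrogen-bond acceptor, whereas the group it replaces is a ring of carbon only.

Among the compounds with values here, every measured step so far concerns this same oxygen, and none of them moved the number beyond the scatter; besides the two steps above, a 1.7-fold lower number from compound 1 to compound 2 (0.22 log units; within the scatter). A chain, a branched group and a ring have all left the number close to where it was. No reason appears in these data for the entering group to behave differently, so the step from compound 3 to compound 4 is expected to stay within the scatter, a 1.3-fold lower number from compound 3 to compound 4 (0.10 log units; within the scatter). Compound 4 is therefore estimated at 650 nM in this assay, with a range from 250 nM to 1700 nM.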

Compound 4, half-maximal inhibitory concentration: 1070 nM
The estimate for compound 4 lay 1.6-fold (0.22 log units) below the measured number; low and high end bracket the measured number.
By their numbers in this assay, from the lowest: compounds 2, 1, 3 and 4 (each within the scatter of the next, the first and the last beyond it).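

Within the data shown here, this is the first step at this oxygen to clear the scatter: a 2.4-fold higher number from compound 2 to compound 4 (0.39 log units; beyond the scatter), with ethoxy in place of hydrogen on a saturated chain carbon, two bonds along the chain from an oxygen on an aromatic ring. Among these compounds, the position is therefore not fully indifferent to what it carries, although the effect is modest and this is the only pair among the four compounds that can be told apart. Among the compounds shown here, the other two steps give no such signal, a 1.3-fold higher number from compound 3 to compound 4 (0.11 log units; within the scatter) and a 1.5-fold higher number from compound 1 to compound 4 (0.17 log units; within the scatter), so the entering group cannot be separated from either the 3-methylcyclopentyl group or the 3,3,3-trifluoropropyl group, and nothing available accounts for the one step that does stand out.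

The compounds shown leave open whether the higher number in compound 4 comes from the ether oxygen itself or simply from the larger group, a question that a longer chain of carbon only could help to settle. They also leave open how this oxygen's substituent would behave if it carried an amine or a carboxylic acid.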